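This account rests on a few compounds, and the source may have more. Where it says the series, first, only, none or still open, it means among the compounds named here.

Measured compounds:
compound 1 `COC(=O)C1=C(C)N=C(C)/C(=C(/O)OC)C1c1cccc(N/C(=N/CCNC2CCN(c3ccccc3C#N)CC2)NC#N)c1`, 3 nM in an assay on SK-N-MC cells for inhibition of Neuropeptide Y receptor type 1 (Homo sapiens); on this read-out lower numbers stand for stronger inhibition and higher numbers for weaker inhibition
compound 2 `COC(=O)C1=C(C)N=C(C)/C(=C(/O)OC)C1c1cccc(N/C(=N/CCNC2CCN(c3ccccc3OC)CC2)NC#N)c1`, 4 nM
compound 3 `COC(=O)C1=C(C)N=C(C)/C(=C(/O)OC)C1c1cccc(NC(=O)NCCNC2CCN(c3ccccc3C(F)(F)F)CC2)c1`, 31 nM

Compound 3 gives the highest number of the three; the nearest is compound 2, and compound 1 is furthest, both gaps beyond the scatter. Compound 4 `COC(=O)C1=C(C)N=C(C)/C(=C(/O)OC)C1c1cccc(NC(=O)NCCNC2CCN(c3cccc(Cl)c3)CC2)c1` differs from compound 3 in one place: 3-chlorophenyl in place of 2-(trifluoromethyl)phenyl on an amine nitrogen in a ring. Within the data shown here, the only measured step on the same ring is a 1.3-fold higher number from compound 1 to compound 2 (0.12 log units; within the scatter), which replaced one substituent on that aryl by another without a step beyond the scatter. It bears on the present change only loosely, as compound 1 and compound 2 carry a different linker than compound 3. With that thin basis, no step beyond the scatter is expected, a 1.0-fold lower number from compound 3 to compound 4 (0.01 log units; within the scatter). Compound 4 is therefore estimated at 30 nM, within 10 nM to 90 nM.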

Compound 4, half-maximal inhibitory concentration: 8 nM
For compound 4 the middle estimate is 3.8-fold (0.57 log units) above the measured one; measured number below the stated range.
By their numbers in this assay, from the lowest: compounds 1, 2 and 4 (each within the scatter of the next, the first and the last beyond it); then compound 3.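

In this assay, 3-chlorophenyl in place of 2-(trifluoromethyl)phenyl on the amine nitrogen in the ring gives a 3.9-fold lower number from compound 3 to compound 4 (0.59 log units; beyond the scatter), the only step beyond the scatter at this position among the compounds shown. The aryl group on this nitrogen therefore affects the read-out with the linker of compound 3, which a 1.3-fold higher number from compound 1 to compound 2 (0.12 log units; within the scatter), on a different linker, did not show. No measurement at hand explains this step.

The change swaps both the substituent and its place on the phenyl, and 2-chlorophenyl or 3-(trifluoromethyl)phenyl would separate the two. Also open, as far as these compounds go, is whether 3-chlorophenyl gives a similar step on the linker of compound 1.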